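The compounds below may be only part of what the source reports. "The series", "measured", "known", "first", "only" and "open" are said of these compounds alone.

Measured compounds:
- compound 1, `NS(=O)(=O)c1ccc(-c2oc3ccccc3c(=O)c2-c2ccc(F)cc2)cc1`: in an assay on isolated protein for inhibition of prostaglandin G/H synthase 1 (Mus musculus), tested at 10 ug/mL (on this read-out lower numbers stand for less inhibition and higher numbers for more inhibition at the one concentration tested (going by the name of the read-out)), compound 1 gives 67%
- compound 2, `CS(=O)(=O)c1ccc(-c2oc3ccccc3c(=S)c2-c2ccc(F)cc2)cc1`: in this assay compound 2 gives < 5%, which is a limit of the assay and not a number
- compound 3, `COc1ccc(-c2c(-c3ccc(S(C)(=O)=O)cc3)oc3ccccc3c2=S)cc1`: in this assay compound 3 gives < 5%, again a limit of the assay

Going by the values given here, compound 1 therefore stands alone as the one compound with a real number; the other two values sit at the limit of < 5% in this assay, at which 2 of the 3 values shown sit. Among the compounds with values here, the only measured step that shares the change of interest is a step that the two limits leave unreadable from compound 2 to compound 3, and since both ends are limits its size cannot be read. Compounds 2 and 3 also differ from compound 1 elsewhere, so their values say nothing about compound 1 itself.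

Compound 4, `COc1ccc(-c2c(-c3ccc(S(N)(=O)=O)cc3)oc3ccccc3c2=O)cc1`, carries the same change applied to compound 1: methoxy in place of fluoro on an aromatic carbon. No readable step bears on it, so the expected step of a number 7 percentage points lower from compound 1 to compound 4 (within the scatter) is set at none beyond the scatter. For compound 4 the estimate in this assay is 60%, in a range from 30% to 85%.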

Compound 4, a percentage reported as inhibition, at one concentration (the size of the read-out at that concentration, not a potency): 84%
Compound 4: the middle estimate sits 24 percentage points below what was measured; low and high end bracket the measured number.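

In this assay, the change from 4-fluorophenyl to 4-methoxyphenyl on the core of compound 1 gives a number 17 percentage points higher from compound 1 to compound 4 (beyond the scatter), so this position accepts methoxy in place of fluoro and inhibition rises rather than falls. The earlier pair could not show this, because the same change between compound 2 and compound 3 joins two values that are both limits and its size cannot be read: the limit of < 5% in this assay, at which 2 of the 4 values shown sit. The rise is still one pair on one core, and it is read at a single concentration, so it is not a measure of potency.

From the compounds shown here alone, whether the rise follows from methoxy alone or would also appear with a hydroxyl, an amine or a longer chain such as ethoxy at this position stays open. Also open, going by these compounds, is how compound 4 compares at other concentrations, which would show whether the difference holds across a dose range.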